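Aminoquinone series: aryl amine in place of benzyl amine

This account rests on a few compounds, and the source may have more. Where it says the series, first, only, none or still open, it means among the compounds named here.

Compound 1 `O=C1C=C(NCc2ccccc2)C(=O)c2c1nc1n2[C@H]2OC[C@@H](O)[C@H]2OC1` and compound 2 `O=C1C(N2CCC2)=CC(=O)c2c1nc1n2[C@H]2OC[C@@H](O)[C@H]2OC1` have both been run in a functional assay on MCF7 cells (Homo sapiens) for inhibition, read by sulforhodamine B assay; on this read-out higher numbers stand for weaker inhibition and lower numbers for stronger inhibition. For compound 1 the read-out is a limit of the assay, not a number: > 8000 nM. For compound 2 the read-out is likewise only a limit, > 16000 nM. Compound 1 therefore stands at one of the two limits seen so far, (the limit of > 8000 nM in this assay, at which 1 of the 2 values shown sits), the other being (the limit of > 16000 nM in this assay, at which 1 of the 2 values shown sits). Compound 3 `CCOc1ccccc1NC1=CC(=O)c2nc3n(c2C1=O)[C@H]1OC[C@@H](O)[C@H]1OC3` carries 2-ethoxyphenyl in place of benzyl on an amine nitrogen. Within the data shown here, no step between measured compounds is available to judge this change; the step from compound 1 to compound 3 in this assay is expected to be small, a step that the limit leaves unreadable from compound 1 to compound 3, and may again end at a limit. Compound 3 is estimated at 10000 nM, within 3000 nM to 30000 nM.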

Compound 3, half-maximal inhibitory concentration: > 4000 nM
Compound 3: only a limit was reported; the forecaster's own chance of this, stated with the estimate: 65%; the middle value does not contradict the limit.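

Compound 1 and compound 3 both end at limits of the assay in this assay, so no step can be read between them. The compounds shown leave open how 2-ethoxyphenyl compares with benzyl on this amine nitrogen.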